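4-methylpiperidin-1-yl for pyrrolidin-1-yl on the chain carbon

The source may hold more compounds than are shown below. What is called first, only, known or untested is meant among the compounds shown, and "the series" means these compounds.

Compound 1 `COc1cc2c(Oc3ccc(NC(=O)c4nn(-c5cccc(F)c5)c(=O)c5ccccc45)cc3F)ccnc2cc1OCCCN1CCCC1` and compound 2 `COc1cc2c(Oc3ccc(NC(=O)c4nn(-c5ccc([N+](=O)[O-])cc5)c(=O)c5ccccc45)cc3F)ccnc2cc1OCCCN1CCCC1` share one core and differ only in the group on an aromatic nitrogen. In a functional assay on MDA-MB-231 cells (Homo sapiens) for cytotoxicity, read by MTT assay, with a stated time of 72 h (on this read-out higher numbers stand for weaker inhibition and lower numbers for stronger inhibition), compound 1 gives 880 nM, while compound 2 gives 2980 nM; the step of a 3.4-fold higher number from compound 1 to compound 2 (0.53 log units; beyond the scatter). Compound 2 therefore stands highest of the two numbers, with compound 1 as its nearest neighbour.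

Compound 3 `COc1cc2c(Oc3ccc(NC(=O)c4nn(-c5ccc([N+](=O)[O-])cc5)c(=O)c5ccccc45)cc3F)ccnc2cc1OCCCN1CCC(C)CC1` keeps the 4-nitrophenyl of compound 2 and alters the saturated chain instead: 4-methylpiperidin-1-yl in place of pyrrolidin-1-yl on a saturated chain carbon, three bonds along the chain from an oxygen on an aromatic ring. Within the data shown here, no measured step touches this place. Among the measured compounds shown here, the single step in hand, a 3.4-fold higher number from compound 1 to compound 2 (0.53 log units; beyond the scatter), concerns the substituent on the aromatic nitrogen and offers no guide for a change on a saturated chain carbon, three bonds along the chain from an oxygen on an aromatic ring. With nothing bearing on it, no step beyond the scatter is expected in this assay in either direction, and the range is kept wide to reflect that. Compound 3 is thus estimated at 3000 nM, between 1200 nM and 7500 nM. The expected step of a 1.0-fold higher number from compound 2 to compound 3 (0.00 log units; within the scatter) is taken to fall within the scatter.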

Compound 3, half-maximal inhibitory concentration: 4010 nM
For compound 3 the middle estimate is 1.3-fold (0.13 log units) below the measured one; measured number inside the range.
By their numbers in this assay, from the lowest: compound 1; then compounds 2 and 3 (each within the scatter of the next).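

In this assay, among these compounds, the exchange on a saturated chain carbon, three bonds along the chain from an oxygen on an aromatic ring, gives a 1.3-fold higher number from compound 2 to compound 3 (0.13 log units; within the scatter) and thus provides the first reading at this place. With the 4-nitrophenyl group held constant, replacing pyrrolidin-1-yl, a five-membered non-aromatic ring, with 4-methylpiperidin-1-yl, a six-membered non-aromatic ring carrying a methyl group, leaves the number within the scatter, so this one pair shows no separation between the two chain ends. No measured information available here accounts for this result.

From the compounds shown here alone, it remains open whether the same exchange would also stay within the scatter on the 3-fluorophenyl compound, since compound 1 and compound 3 differ in two places and cannot be compared directly. Also open, going by these compounds, is how this assay would respond to other chain ends, such as morpholin-4-yl or 4-methylpiperazin-1-yl, to a primary amine in their place, or to a chain longer than the 3-(4-methylpiperidin-1-yl)propyl group.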